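Replacing 4-chlorophenyl with methyl in compound 1

A few compounds are considered here, and "the series" means these few. Any claim that something is new, unique, unknown or untested is made for them only; others in the source may bear on it.

Compound 1 `CC(=O)O[C@@H]1C=CC(=O)O[C@@H]1[C@@H](COC(=O)c1ccc(Cl)cc1)OC(C)=O`: 15700 nM
Compound 2 `COc1ccc(/C=C/C(=O)OC[C@@H](OCc2ccccc2)[C@H]2OC(=O)C=C[C@H]2OCc2ccccc2)cc1`: 4250 nM

In a functional assay on A549 cells (Homo sapiens) for antiproliferative activity, read by MTT assay, with a stated time of 6 days (on this read-out lower numbers stand for stronger inhibition and higher numbers for weaker inhibition), compound 1 has the higher of the two numbers, and compound 2 lies lower by more than the scatter. Compound 3 `CC(=O)OC[C@@H](OC(C)=O)[C@H]1OC(=O)C=C[C@H]1OC(C)=O` has not yet been measured. It carries methyl in place of 4-chlorophenyl on a carbonyl carbon. Among the measured compounds shown here, no measured step shows this change, so its direction remains open. The estimated 1.3-fold lower number from compound 1 to compound 3 (0.12 log units; within the scatter) is expected to stay within the scatter in this assay. Compound 3 is expected at 12000 nM, with an estimated range from 3000 nM to 50000 nM.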

Compound 3, half-maximal inhibitory concentration: 12600 nM
For compound 3 the middle estimate is 1.1-fold (0.02 log units) below the measured one, and the stated range covers the measured number.
By their numbers in this assay, from the lowest: compound 2; then compounds 3 and 1 (each within the scatter of the next).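

In this assay, among the compounds shown here, the change gives a 1.2-fold lower number from compound 1 to compound 3 (0.10 log units; within the scatter) and is the first direct reading at this position. On a carbonyl carbon, methyl in place of 4-chlorophenyl leaves the number within the scatter, so the 4-chlorophenyl ring is not needed to keep this level of activity in this pair. No measurement available here offers an explanation for this result. From the compounds shown here alone, whether an amine or a longer chain on this carbonyl carbon would shift the number beyond the scatter remains open. So does whether an unsubstituted phenyl would behave like either group.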